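A few compounds are considered here, and "the series" means these few. Any claim that something is new, unique, unknown or untested is made for them only; others in the source may bear on it.

Values in a functional assay (aorta) with Rattus norvegicus as the target, in the presence of a further agent that is not named here (on this read-out higher numbers stand for an effect only at larger amounts of compound and lower numbers for an effect already at smaller amounts), so far:

- compound 1 `COC(=O)C1=C(C)N=C(C)/C(=C(\O)OC)C1c1cccc([N+](=O)[O-])c1` gives 3.4 nM
- compound 2 `COC(=O)C1=C(C)N=C(C)/C(=C(/O)OC)C1c1ccccc1OCCO[N+](=O)[O-]` gives 56 nM
- compound 3 `COC(=O)C1=C(C)N=C(C)/C(=C(/O)OC)C1c1cccc(OCc2nonc2C(N)=O)c1` gives 3500 nM

Compound 2 (56 nM) holds the middle place among the three numbers. Compound 1 (3.4 nM) lies lower and compound 3 (3500 nM) lies higher, and both gaps are beyond the scatter.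

Compound 4 `COC(=O)C1=C(C)N=C(C)/C(=C(/O)OC)C1c1ccccc1OCc1c(C)no[n+]1[O-]` has not yet been measured. Its change from compound 2 is a group of 7 heavy atoms (3 carbon, 2 nitrogen, 2 oxygen; one five-membered aromatic ring with 3 hetero atoms) in place of a group of 5 heavy atoms (1 carbon, 1 nitrogen, 3 oxygen; no ring), on a saturated chain carbon bound to an oxygen on an aromatic ring and it replaces the (nitrooxy)methyl group with a group that has no common name. Among the compounds with values here, no pair of measured compounds differs in one place only, so no measured step isolates this change and the expectation rests on thin evidence. Within the data shown here, the one measured compound with a five-membered aromatic ring in its side chain is compound 3 (3500 nM), which has the highest number so far, though it differs from compound 2 in more than this ring. On that basis, a move towards a higher number is expected, beyond the scatter but probably short of the value of compound 3. The expected step is (a 5.4-fold higher number from compound 2 to compound 4 (0.73 log units; beyond the scatter)) in this assay and remains uncertain. For compound 4 the estimated value is (300 nM) with an expected range from (50 nM) to (2000 nM).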

Compound 4, half-maximal effective concentration: 78 nM
For compound 4 the middle estimate is 3.8-fold (0.59 log units) above the measured one; low and high end bracket the measured number.
By their numbers in this assay, from the lowest: compound 1; then compounds 2 and 4 (each within the scatter of the next); then compound 3.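

In this assay, within the data shown here, the one single-place pair gives a 1.4-fold higher number from compound 2 to compound 4 (0.14 log units; within the scatter), so on a saturated chain carbon bound to an oxygen on an aromatic ring, the (nitrooxy)methyl group can be replaced by the larger group with a five-membered aromatic ring, and the two numbers stay within the scatter of each other. The open chain is thus not required for a number of this size at this place, and neither is the absence of a ring. Nothing at hand explains why the two groups read alike on this measurement.

This one pair does not show which part of the entering group matters, since a ring carrying an ethyl or a phenyl group instead of its methyl group would be needed to separate the ring from its substituent. Also open, from the compounds shown here alone, is how far this place accepts other kinds of group, such as a longer chain ending in the nitrooxy group, an amine or a carboxylic acid.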